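Adding a Cyclopropyl Ring to Compound 1

The source may report more compounds than this note shows. Statements on the series, on what has been measured and on what is new or still open speak of the compounds shown alone.

Of the compounds shown here, three have so far been measured in a physicochemical assay for lipophilicity, using the shake flask method; on this read-out higher numbers stand for higher lipophilicity and lower numbers for lower lipophilicity. Compound 1, `C[C@H](Oc1ccc(/C=C/C(=O)O)cc1)c1c(Cl)ccc(F)c1Cl`, gives 2.8 in this assay. Compound 2, `C[C@H](Oc1cccc(C2CC2)n1)c1c(Cl)ccc(F)c1Cl`, gives 4.9, and compound 3, `C[C@H](Oc1ccnc(C2CC2)c1)c1c(Cl)ccc(F)c1Cl`, gives 4.3. Compound 1 therefore stands lowest of the three: compound 3 lies nearest, at a number higher by a margin beyond the usual scatter, and compound 2 lies furthest, higher still and also beyond the scatter. No two of these measured compounds differ in only one place, so none of the gaps between them can be read as the result of a single change.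

Compound 4, `C[C@H](Oc1ccc(/C=C/C(=O)O)c(C2CC2)c1)c1c(Cl)ccc(F)c1Cl`, has not yet been measured. It differs from compound 1 by cyclopropyl in place of hydrogen on an aromatic carbon. The place of the change is an aromatic carbon of the six-membered aromatic ring of carbon only, ortho to the 2-carboxyethenyl group and meta to a large group.

Within the data shown here, no single-change step between measured compounds is available. The size of the step to compound 4 can only be estimated. The step is expected to be a rise well beyond the scatter, a number 1.10 log units higher from compound 1 to compound 4 (beyond the scatter). Compound 4 is accordingly expected to give about 3.9 in this assay, with a likely range from 3.3 to 4.5.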

Compound 4, distribution coefficient: 3.6
For compound 4 the middle estimate is 0.30 log units above the measured one; the measured number falls inside the stated range.
By their numbers in this assay, from the lowest: compound 1; then compound 4; then compound 3; then compound 2.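

In this assay, among these compounds, cyclopropyl in place of hydrogen on an aromatic carbon ortho to the 2-carboxyethenyl group gives a number 0.80 log units higher from compound 1 to compound 4 (beyond the scatter) as the one single-change step. Until this pair, the gaps between compounds each mixed several differences, so none could be tied to one group at one place. This step ties a change beyond the usual scatter to this one place on the core of compound 1, with the 2-carboxyethenyl group kept and meta to a large group, as it stands in compound 1. No measurement at hand explains the size of this step.

On these data alone, what stays open is whether another group at this same place, such as methyl, a longer chain like n-propyl, or an amine, would give a smaller or a larger step than cyclopropyl does. A single pair also cannot say whether cyclopropyl on a different aromatic carbon, or on a compound lacking the 2-carboxyethenyl group, would move the number by a similar amount.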